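Butyl on the Amide Nitrogen of Compound 2

The compounds below may be only part of what the source reports. "The series", "measured", "known", "first", "only" and "open" are said of these compounds alone.

Of the compounds shown here, two have been measured in an assay on isolated protein for inhibition of serine/threonine-protein kinase PAK 4 (Homo sapiens); on this read-out higher numbers stand for weaker inhibition and lower numbers for stronger inhibition. Compound 1 `COC(=O)c1cc2c(Nc3ccccc3)[nH]nc2s1` gives 37000 nM in this assay. Compound 2 `Cc1n[nH]c2sc(C(N)=O)cc12` reaches only a limit of the assay, > 20000 nM, so where it stands is known only as that limit (the limit of > 20000 nM in this assay, at which 1 of the 2 values shown sits). Compound 1 and compound 2 share a core but differ in more than one place, so their two values show only that both are weak inhibitors. Compound 3 `CCCCNC(=O)c1cc2c(C)n[nH]c2s1` differs from compound 2 by butyl in place of hydrogen on an amide-type nitrogen. Going by the values given here, no measured step covers this change, so the expectation rests on compound 2 alone, whose value is only a limit. Compound 3 is expected to remain weak, with a step that the limit leaves unreadable from compound 2 to compound 3 that need not exceed the usual scatter. The estimate for compound 3 is 25000 nM, between 8000 nM and 80000 nM.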

Compound 3, half-maximal inhibitory concentration: > 20000 nM
Compound 3 gave a limit, no number (the forecaster's own chance of this, stated with the estimate: 50%); the middle value is on the limit's open side.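

In this assay compound 3 reaches only the limit > 20000 nM and compound 2 also sits at a limit, so no step between compound 2 and compound 3 can be read: the limit of > 20000 nM in this assay, at which 2 of the 3 values shown sit.

The compounds shown leave open whether butyl in place of hydrogen on the amide-type nitrogen changes inhibition at all.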